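Compound 3 to compound 4: trifluoromethoxy replaces nitro

The source may report more compounds than this note shows. Statements on the series, on what has been measured and on what is new or still open speak of the compounds shown alone.

In a functional assay on A2780 cells (Homo sapiens) for inhibition, with a stated time of 72 h (on this read-out higher numbers stand for weaker inhibition and lower numbers for stronger inhibition), compound 1 (`CN1c2ccc(NC(=O)Nc3ccc([N+](=O)[O-])cc3)cc2C(C)(C)C(=O)C1(C)C`) gives 3800 nM, compound 2 (`CN1c2ccc(NC(=O)Nc3ccc([N+](=O)[O-])cc3)cc2C(C)(C)C(O)C1(C)C`) gives 8400 nM and compound 3 (`CN1c2ccc(NC(=S)Nc3ccc([N+](=O)[O-])cc3)cc2C(C)(C)C(O)C1(C)C`) gives 10000 nM. Compound 3 thus lies within the scatter of compound 2, and beyond the scatter of compound 1 on the side of weaker inhibition. Compound 4 (`CN1c2ccc(NC(=S)Nc3ccc(OC(F)(F)F)cc3)cc2C(C)(C)C(O)C1(C)C`) has trifluoromethoxy in place of nitro on an aromatic carbon, para to a large group: trifluoromethoxy in place of nitro on an aromatic carbon. Among the compounds with values here, no measured pair isolates this change, so the expectation is a judgement with a wide range. The expected step in this assay is a 1.8-fold lower number from compound 3 to compound 4 (0.26 log units; within the scatter), a modest move toward stronger inhibition. For compound 4 the estimated value is 5500 nM, with an expected range of 2000 nM to 14000 nM.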

Compound 4, half-maximal inhibitory concentration: 13100 nM
For compound 4 the middle estimate is 2.4-fold (0.38 log units) below the measured one; the measured number falls inside the stated range.
By their numbers in this assay, from the lowest: compound 1; then compounds 2, 3 and 4 (each within the scatter of the next).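

Compounds 1, 2 and 3 all carry nitro on this aromatic carbon, so they gave no reading of that group's replacement. In this assay, trifluoromethoxy in place of nitro, para to a large group, gives a 1.3-fold higher number from compound 3 to compound 4 (0.12 log units; within the scatter), so this assay does not separate the two groups at this position on the core of compound 3. No measurement at hand offers an explanation for this result.

As far as these compounds go, whether an amine, a carboxylic acid or a methoxy group here would separate from nitro and trifluoromethoxy remains open. Also open, from the compounds shown here alone, is whether the same replacement would read alike on compound 1.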